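A few compounds are considered here, and "the series" means these few. Any claim that something is new, unique, unknown or untested is made for them only; others in the source may bear on it.

In a functional assay on HCT-116 cells (Homo sapiens) for antiproliferative activity, read by CellTiter-Glo, with a stated time of 72 h (on this read-out lower numbers stand for stronger inhibition and higher numbers for weaker inhibition), compound 1, `O=C(NO)c1ccc(/C=C/c2ccnc(-c3cccnc3)c2)cc1`, gives 5140 nM, while compound 2, `Cc1ccc(-c2cc(/C=C/c3ccc(C(=O)NO)cc3)ccn2)c(F)c1`, gives 800 nM, the lower of the two numbers. Among the measured compounds shown here, the only measured step, a 6.4-fold lower number from compound 1 to compound 2 (0.81 log units; beyond the scatter), is modest but beyond the scatter, and it came with 2-fluoro-4-methylphenyl in place of pyridin-3-yl on an aromatic carbon. Compound 3, `O=C(NO)c1ccc(/C=C/c2ccnc(-c3ccsc3)c2)cc1`, has not yet been measured. It carries thiophen-3-yl in place of 2-fluoro-4-methylphenyl at that same place, next to the ring nitrogen: thiophen-3-yl in place of 2-fluoro-4-methylphenyl on an aromatic carbon. For the measured compounds named here, no measured compound carries thiophen-3-yl, so the one step above is the only guide. Compound 1, which also has a hetero atom in the ring at this place, gives 5140 nM, so a partial move back towards that number seems likely. A step of a 2.5-fold higher number from compound 2 to compound 3 (0.40 log units; beyond the scatter) is therefore expected in this assay, towards a higher number. For compound 3 the estimate is 2000 nM, with an expected range of 700 nM to 5500 nM.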

Compound 3, half-maximal inhibitory concentration: 1910 nM
Beside the measured number, compound 3's estimate is 1.0-fold (0.02 log units) above it, and the stated range covers the measured number.
By their numbers in this assay, from the lowest: compound 2; then compound 3; then compound 1.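

In this assay the place next to the ring nitrogen now separates three groups rather than two: thiophen-3-yl gives a 2.4-fold higher number from compound 2 to compound 3 (0.38 log units; beyond the scatter) and also a 2.7-fold lower number from compound 1 to compound 3 (0.43 log units; beyond the scatter). A ring with a hetero atom at this place therefore need not read as high as compound 1, and thiophen-3-yl, with fewer heavy atoms than 2-fluoro-4-methylphenyl, retains part of the drop seen with that group, though these compounds cannot separate ring size from ring substitution. No measurement available here accounts for these differences.

On these data alone, whether the fluorine or the methyl of compound 2 goes with its lower number remains open, as does the reading of an unsubstituted phenyl or a furan-3-yl group. The compounds shown also say nothing about an amine or a carboxylic acid on the ring at this place.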